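This account rests on a few compounds, and the source may have more. Where it says the series, first, only, none or still open, it means among the compounds named here.

Two compounds have been measured in an ADME assay on S9 fraction from liver (Mus musculus) for metabolic stability, read by LC-MS, using NADPH, with a stated time of 45 min, tested at 3 uM, in the presence of a further agent that is not named here; on this read-out lower numbers stand for lower hepatic extraction and higher numbers for higher hepatic extraction:

Compound 1 `COc1ccc(-n2cnc3cnc(-c4ccccc4)cc32)cc1OC` gives 1.
Compound 2 `COc1ccc(-n2cnc3cnc(-c4ccc(F)cc4C)cc32)cc1OC` gives 1.

Compound 2 stands level with compound 1 on the numbers shown: the step of no change at the digits printed from compound 1 to compound 2 (within the scatter) lies within the scatter, and both compounds sit at the top of the read-out in this assay. Compound 3 `COc1ccc(-n2cnc3cnc(-c4cc(F)ccc4C)cc32)cc1OC` has not yet been measured. It differs from compound 2 by 5-fluoro-2-methylphenyl in place of 4-fluoro-2-methylphenyl on an aromatic carbon. For the measured compounds named here, only one measured step bears on this change, the one in which 4-fluoro-2-methylphenyl took the place of phenyl, and it left the number where it was. Shifting the fluorine within that ring is a smaller change, and no measured step gives reason to expect the read-out to leave its present level. Compound 3 is therefore expected to show no step beyond the scatter, no change at the digits printed from compound 2 to compound 3 (within the scatter), in this assay. The estimate for compound 3 is 1, with a range from 0.9 to 1.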

Compound 3, hepatic extraction ratio: 1
Compound 3: middle estimate and measured number agree at the digits printed; measured number inside the range.
By their numbers in this assay, from the lowest: compounds 1, 2 and 3 (each within the scatter of the next).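

In this assay the change of ring shows no change at the digits printed from compound 2 to compound 3 (within the scatter), so at this aromatic carbon the read-out does not separate 4-fluoro-2-methylphenyl from 5-fluoro-2-methylphenyl. Set against phenyl, the new ring gives no change at the digits printed from compound 1 to compound 3 (within the scatter), which makes it the second fluorinated, methylated phenyl ring to leave the number where phenyl had it. No measurement at hand offers an explanation for this level.

All three compounds sit at the top of the read-out, so these values cannot show whether any of the rings differ beyond that level. Going by these compounds, it remains open whether a group of another kind on this carbon, such as a piperazine or a carboxylic acid, would bring the number down, and whether changing the two methoxy groups elsewhere on the shared core would do so.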